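A few compounds are considered here, and "the series" means these few. Any claim that something is new, unique, unknown or untested is made for them only; others in the source may bear on it.

Measured so far in a physicochemical assay for solubility, at pH 7.4; on this read-out higher numbers stand for higher solubility and lower numbers for lower solubility:
compound 1 `O=C(NCc1ccc(-c2noc(CCC3CC3)n2)cc1)[C@H]1NCC[C@@H]1O`: compound 1 gives > 50 ug/mL, which is a limit of the assay and not a number.
compound 2 `CCCCCCCc1cc(-c2ccc(CNC(=O)[C@H]3NCC[C@@H]3O)cc2)n[nH]1`: compound 2 gives 3.7 ug/mL.
compound 3 `CC[C@H](NC(=O)[C@H]1NCC[C@@H]1O)c1ccc(-c2noc(CCC3CCCC3)n2)cc1`: compound 3 gives 36 ug/mL.

Compound 1 thus stands at the upper bound of this assay, the point described by the limit of > 50 ug/mL in this assay, at which 1 of the 3 values shown sits, and its true value is not fixed by the numbers shown. The next compound, compound 4 `CCCCCCCCc1nc(-c2ccc(CNC(=O)[C@H]3NCC[C@@H]3O)cc2)no1`, differs from compound 1 in one place: hexyl in place of cyclopropyl on a saturated chain carbon, two bonds along the chain from an aromatic carbon. Going by the values given here, no pair of measured compounds shows this change directly, so no measured step can be cited for it. What the numbers do show is that compound 2, which carries a heptyl chain on its own core, sits far below compound 3, a gap beyond the usual scatter, and below the bound at which compound 1 rests.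

On that footing a downward step is expected, of about an at least 16-fold lower number from compound 1 to compound 4 (1.22 log units; beyond the scatter), well beyond the scatter. Compound 4 is estimated at 3 ug/mL in this assay, with a range of 0.8 ug/mL to 12 ug/mL.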

Compound 4, solubility: 4 ug/mL
Beside the measured number, compound 4's estimate is 1.3-fold (0.12 log units) below it, and the stated range covers the measured number.
By their numbers in this assay, from the lowest: compounds 2 and 4 (each within the scatter of the next); then compound 3. At a limit, above all of these: compound 1.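

In this assay, the place on a saturated chain carbon, two bonds along the chain from an aromatic carbon, now has its first direct reading. Hexyl in place of cyclopropyl there gives an at least 12-fold lower number from compound 1 to compound 4 (1.09 log units; beyond the scatter), so this place on the shared core is not indifferent to the group it carries. That step gives only the least possible size of the change, as compound 1 rests on a limit and not a number: the limit of > 50 ug/mL in this assay, at which 1 of the 4 values shown sits.

This single step does not separate the loss of the cyclopropyl ring from the gain in chain length, since both change together. From the compounds shown here alone, how a shorter open chain such as propyl, or a hexyl chain ending in an amine or a carboxylic acid, would read at this place remains open.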